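Swapping fluoro for bromo: an expected step

The source may hold more compounds than are shown below. What is called first, only, known or untested is meant among the compounds shown, and "the series" means these compounds.

Measured so far in a functional assay on MCF-10A cells (Homo sapiens) for inhibition; a lower number here means a stronger inhibitor, a higher number a weaker inhibitor:
- compound 1 `O=C(/C=C/c1ccc(F)c(Cl)c1)c1ccc(B(O)O)cc1` gives 25000 nM
- compound 2 `O=C(/C=C/c1ccc(I)cc1)c1ccc(O)cc1` gives 15000 nM
- compound 3 `O=C(/C=C/c1ccc(F)c(F)c1)c1ccc(B(O)O)cc1` gives 18000 nM

Compound 3 stands second highest of these three numbers. Its nearest neighbour is compound 2, whose value sits within the scatter of it, and its furthest is compound 1, also within the scatter; so the three measured compounds cannot be told apart on these numbers.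

Compound 4 `O=C(/C=C/c1ccc(F)c(Br)c1)c1ccc(B(O)O)cc1` has not yet been measured. It differs from compound 3 in one place: bromo in place of fluoro on an aromatic carbon.

Going by the values given here, only one measured step bears on this change. Going a 1.4-fold lower number from compound 1 to compound 3 (0.14 log units; within the scatter), the reverse swap of halogens at the same place, moved the number hardly at all. Bromo enters where chloro and fluoro have already been compared, and the single relevant step suggests a halogen swap here changes little. The expected step in this assay is therefore small, with a slight lean toward a higher number, and likely within the scatter: a 1.2-fold higher number from compound 3 to compound 4 (0.09 log units; within the scatter) is the expected step from compound 3 to compound 4.

Compound 4 is thus estimated at 22000 nM, with a range from 9000 nM to 50000 nM.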

Compound 4, half-maximal inhibitory concentration: 17000 nM
For compound 4 the middle estimate is 1.3-fold (0.11 log units) above the measured one; the range from low to high includes it.
By their numbers in this assay, from the lowest: compounds 2, 4, 3 and 1 (each within the scatter of the next).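

In this assay, bromo in place of fluoro on this aromatic carbon gives a 1.1-fold lower number from compound 3 to compound 4 (0.02 log units; within the scatter) and bromo in place of chloro gives a 1.5-fold lower number from compound 1 to compound 4 (0.17 log units; within the scatter); with a 1.4-fold lower number from compound 1 to compound 3 (0.14 log units; within the scatter), all three comparisons among these halogens are now in hand. Where the earlier compounds compared only fluoro and chloro, this position, ortho to a fluoro group and meta to a large group, now shows three halogens that cannot be told apart in this assay, since each step lies within the scatter. No separate measurement is available to help interpret this result.

As far as these compounds go, these three compounds cover only halogens at this position, so it remains open whether a group of another kind there, such as an amine, a carboxylic acid or a methoxy group, would also leave the number within the scatter. Compound 2 differs from the others in more than one place, so its comparisons cannot be read as single changes, and the separate contribution of the boronic acid on the other ring stays unresolved.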